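Hydroxyphenyl position series: working notes and one estimate

The source may report more compounds than this note shows. Statements on the series, on what has been measured and on what is new or still open speak of the compounds shown alone.

Measured so far in a functional assay on DU-145 cells (Homo sapiens) for cytotoxicity, read by CCK-8 assay, with a stated time of 4 days; a higher number here means a weaker inhibitor, a lower number a stronger inhibitor:
compound 1 `Oc1ccc(-c2cc(-c3ccccc3O)cc(-c3cccc(O)c3)n2)cc1` gives 5370 nM
compound 2 `Oc1ccccc1-c1cc(-c2ccccc2O)nc(-c2ccccc2O)c1` gives 5040 nM
compound 3 `Oc1cccc(-c2cc(-c3ccccc3O)cc(-c3ccccc3O)n2)c1` gives 3980 nM

All three compounds share a core and differ only in where the hydroxyl sits on one of the three hydroxyphenyl groups. Compound 2 differs from compound 3 by 2-hydroxyphenyl in place of 3-hydroxyphenyl on an aromatic carbon; in this assay that change gave a 1.3-fold lower number from compound 2 to compound 3 (0.10 log units; within the scatter). Compound 1 differs from compound 3 by 4-hydroxyphenyl in place of 2-hydroxyphenyl on an aromatic carbon, a change that gave a 1.3-fold higher number from compound 3 to compound 1 (0.13 log units; within the scatter). The three values lie within the scatter of one another, so none of the three can be set apart from the others on these numbers.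

Compound 4 `Oc1ccc(-c2cc(-c3ccccc3O)nc(-c3ccccc3O)c2)cc1` has not yet been measured in this assay. It differs from compound 2 by 4-hydroxyphenyl in place of 2-hydroxyphenyl on an aromatic carbon. This is the same kind of change as from compound 3 to compound 1, but the surroundings are not identical: in compound 4 the changed group sits opposite the ring nitrogen and meta to two 2-hydroxyphenyl groups, whereas in compound 1 it sits next to the ring nitrogen, meta to a 2-hydroxyphenyl group and meta to a 3-hydroxyphenyl group. Because the earlier instance gave a 1.3-fold higher number from compound 3 to compound 1 (0.13 log units; within the scatter), the step expected for compound 4 is a 1.1-fold higher number from compound 2 to compound 4 (0.05 log units; within the scatter), about the same size as that earlier step. The estimate for compound 4 in this assay is 5600 nM, with a likely range from 3000 nM to 10500 nM.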

Compound 4, half-maximal inhibitory concentration: > 50000 nM
Compound 4: only a limit was reported (the forecaster's own chance of this, stated with the estimate: 5%); middle value at least 8.9-fold (0.95 log units) from the limit.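

In this assay compound 4 gives > 50000 nM, which is a limit of the assay and not a number. With 4-hydroxyphenyl in place of 2-hydroxyphenyl opposite the ring nitrogen, the series gives an at least 9.9-fold higher number from compound 2 to compound 4 (0.99 log units; beyond the scatter), and the limit leaves the full size of that step unknown. The change therefore does not carry as a fixed step from the core of compound 3 to the core of compound 2, although two instances set no rule for any other core and give no reason for the gap: the same change on two cores in this assay, a 1.3-fold higher number (0.13 log units; within the scatter) from compound 3 to compound 1 and an at least 9.9-fold higher number (0.99 log units; beyond the scatter) from compound 2 to compound 4, at least 7.3-fold (0.86 log units) apart, beyond the scatter of two such steps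

The compounds shown leave open whether the large step belongs to the 4-hydroxyphenyl group opposite the ring nitrogen as such or depends on the two 2-hydroxyphenyl groups that remain in compound 4, and how a 3-hydroxyphenyl group at that same place would read. They also leave open whether the step is tied to the hydroxyl itself, which a methoxy group, an amine or a carboxylic acid on that phenyl ring at the same place would begin to test.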